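A few compounds are considered here, and "the series" means these few. Any claim that something is new, unique, unknown or untested is made for them only; others in the source may bear on it.

Compound 1 `CCO[C@H]1C[C@@H](c2coc3ccc(F)cc3c2=O)N(c2ccccc2)O1` is measured in a functional assay on PC-3 cells (Homo sapiens) for inhibition, read by sulforhodamine B assay, with a stated time of 48 h (on this read-out lower numbers stand for stronger inhibition and higher numbers for weaker inhibition), at 31700 nM. Compound 3 `CCO[C@H]1C[C@@H](c2coc3ccc(C)cc3c2=O)N(c2ccccc2)O1` carries the change methyl in place of fluoro on an aromatic carbon on the same core, and in this assay compound 3 gives 39000 nM. The step of a 1.2-fold higher number from compound 1 to compound 3 (0.09 log units; within the scatter) is therefore small, and the two compounds are not told apart by this read-out.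

Compound 2 `O=C1[C@H]2[C@H](ON(c3ccccc3)[C@@H]2c2coc3ccc(F)cc3c2=O)C(=O)N1c1ccccc1` rests on a different core; how the two cores differ is not broken down here. In this assay, among the compounds with values here, compound 2 reaches only the limit > 60000 nM, so no number is known for it, only that its value sits at the limit of > 60000 nM in this assay, at which 1 of the 3 values shown sits.

Compound 4 `Cc1ccc2occ([C@@H]3[C@H]4C(=O)N(c5ccccc5)C(=O)[C@H]4ON3c3ccccc3)c(=O)c2c1` has not yet been measured. It stands to compound 2 as compound 3 stands to compound 1, through the same change (methyl in place of fluoro on an aromatic carbon). Within the data shown here, the expected step that the limit leaves unreadable from compound 2 to compound 4 is estimated to be as small as the measured 1.2-fold higher number from compound 1 to compound 3 (0.09 log units; within the scatter), since that is the only guide on this change. Because compound 2 itself gives only the limit > 60000 nM, compound 4 is expected to sit at or beyond that limit too, with an estimate of 80000 nM, between 40000 nM and 200000 nM.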

Compound 4, half-maximal inhibitory concentration: 11100 nM
For compound 4 the middle estimate is 7.2-fold (0.86 log units) above the measured one; measured number outside the range, below it.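

On the other core, methyl in place of fluoro on an aromatic carbon gives an at least 5.4-fold lower number from compound 2 to compound 4 (0.73 log units; beyond the scatter) in this assay. The change therefore does not carry over in size from one core to the other in these two pairs: the same change on two cores in this assay, a 1.2-fold higher number (0.09 log units; within the scatter) from compound 1 to compound 3 and an at least 5.4-fold lower number (0.73 log units; beyond the scatter) from compound 2 to compound 4, at least 6.6-fold (0.82 log units) apart, beyond the scatter of two such steps The two pairs do not show why the cores part, nor how large the step on the second core really is, as compound 2 gives only a limit: the limit of > 60000 nM in this assay, at which 1 of the 4 values shown sits.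

The compounds shown leave open whether the gap between the cores holds for other groups at this same place on the aromatic ring, such as chloro, methoxy or an amine. They also leave open whether a carboxylic acid or a longer chain in that place would give steps that match on both cores or differ as these do.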